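The compounds below may be only part of what the source reports. "The series", "measured", "known", "first", "only" and "open" are said of these compounds alone.

Series notes. The shared core of compound 1 `O=C(Nc1cccc([N+](=O)[O-])c1)N[C@H]1CC[C@H](Oc2ccc(F)cc2)CC1` carries, on an amide-type nitrogen, an aromatic ring that varies across the set. In a functional assay on CRL2813 cells (Homo sapiens) for cytotoxicity, read by sulforhodamine B assay, with a stated time of 5 days (on this read-out higher numbers stand for weaker inhibition and lower numbers for stronger inhibition), compound 1 gives 6700 nM. Compound 2 `COc1ccc(NC(=O)N[C@H]2CC[C@H](Oc3ccc(F)cc3)CC2)cc1` carries 4-methoxyphenyl on that nitrogen; in this assay compound 2 is reported only as a limit of the assay, > 20000 nM. Compound 3 `O=C(Nc1ccccc1I)N[C@H]1CC[C@H](Oc2ccc(F)cc2)CC1` carries 2-iodophenyl there; in this assay compound 3 likewise comes back only as a limit, > 20000 nM. Compound 3 thus stands at the weak end of what is shown, since an at least 2.9-fold higher number from compound 1 to compound 3 (0.47 log units; beyond the scatter) runs from a number to a limit, as does an at least 2.9-fold higher number from compound 1 to compound 2 (0.47 log units; beyond the scatter), while a step that the two limits leave unreadable from compound 2 to compound 3 cannot be sized. The relevant boundary is the limit of > 20000 nM in this assay, at which 2 of the 3 values shown sit.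

Compound 4 `COc1cccc(NC(=O)N[C@H]2CC[C@H](Oc3ccc(F)cc3)CC2)c1` differs from compound 3 as follows: 3-methoxyphenyl in place of 2-iodophenyl on an amide-type nitrogen. The step bearing most directly on this is a step that the two limits leave unreadable from compound 2 to compound 3, which yields no size; the other methoxy-bearing member, compound 2, sits at the limit, and only compound 1 with 3-nitrophenyl returns a number. For compound 4 in this assay no step beyond the scatter is expected, and the estimate is 20000 nM with a range of 7000 nM to 60000 nM. The expected step of a number no higher from compound 3 to compound 4 (the limit leaves the size open) is therefore close to nothing, with a fair chance that only a limit is reported again.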

Compound 4, half-maximal inhibitory concentration: 14000 nM
Compound 4: the middle estimate sits 1.4-fold (0.15 log units) above what was measured, within the range that was stated.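

In this assay, 3-methoxyphenyl on the amide-type nitrogen gives compound 4 a measured number, so a methoxy-bearing aromatic ring in this series is not confined to the assay limit. Methoxy in place of nitro on the aromatic carbon gives a 2.1-fold higher number from compound 1 to compound 4 (0.32 log units; beyond the scatter), the first step in the series with a full size, and it shows that compound 1 keeps only a modest edge over a second 3-substituted member. The other two steps are only floors, an at least 1.4-fold lower number from compound 2 to compound 4 (0.15 log units; that floor lies within the scatter) and an at least 1.4-fold lower number from compound 3 to compound 4 (0.15 log units; that floor lies within the scatter), so neither 3-methoxyphenyl against 4-methoxyphenyl nor 3-methoxyphenyl against 2-iodophenyl can be given a size, and the step between compound 2 and compound 3 cannot be read at all, because those compounds return only limits: the limit of > 20000 nM in this assay, at which 2 of the 4 values shown sit.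

Two groups at this place on the ring give too little to tell whether the number follows the particular group, and an amine, a carboxylic acid or a nitrile on that aromatic carbon would test this directly. Also open, on these data alone, is whether the modest gap between compound 1 and compound 4 holds when the rest of the shared core changes.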